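The source may hold more compounds than are shown below. What is called first, only, known or untested is meant among the compounds shown, and "the series" means these compounds.

Working notes on the series. In a functional assay on MDA-MB-231 cells (Homo sapiens) for inhibition, read by sulforhodamine B assay, tested at 10 uM (on this read-out higher numbers stand for more inhibition at the one concentration tested (going by the name of the read-out) and lower numbers for less inhibition), compound 1 `CN1CCN(c2ccc(C3=NNC(c4ccc(N(C)C)cc4)C3)cc2)CC1` gives 11.4%; compound 2 `CN(C)c1ccc(C2CC(c3ccc(-n4cncn4)cc3)=NN2)cc1` gives 7%; compound 3 `CC(=O)N1N=C(c2ccc(N3CCN(C)CC3)cc2)CC1c1ccc(N(C)C)cc1` gives -1%, the lowest of the three numbers, beyond the scatter only against compound 1. The two steps measured so far are a number 4.4 percentage points lower from compound 1 to compound 2 (within the scatter) and a number 12.4 percentage points lower from compound 1 to compound 3 (beyond the scatter). Compound 4 `CN1CCN(c2ccc(C3=NN(C(=O)CCCl)C(c4ccc(N(C)C)cc4)C3)cc2)CC1` differs from compound 3 by chloromethyl in place of hydrogen on a saturated chain carbon bound to a carbonyl carbon. Among the compounds with values here, neither measured step alters the acetyl already present in compound 3, so no step bears directly on this change, and all three numbers sit low. A step of about a number 4 percentage points higher from compound 3 to compound 4 (within the scatter) is therefore expected, which is none beyond the scatter. Compound 4 is estimated at 3%, in the range -10% to 16%.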

Compound 4, a percentage reported as inhibition, at one concentration (the size of the read-out at that concentration, not a potency): 2.4%
The estimate for compound 4 lay 0.6 percentage points above the measured number; low and high end bracket the measured number.
By their numbers in this assay, from the lowest: compounds 3, 4, 2 and 1 (each within the scatter of the next, the first and the last beyond it).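

With a number 3.4 percentage points higher from compound 3 to compound 4 (within the scatter) as the step, chloromethyl in place of hydrogen on a saturated chain carbon bound to a carbonyl carbon leaves the number in this assay within the scatter. On the amine nitrogen in a ring, (2-chloroethyl)carbonyl in place of hydrogen gives a number 9 percentage points lower from compound 1 to compound 4 (within the scatter) while acetyl on the same nitrogen gives a number 12.4 percentage points lower from compound 1 to compound 3 (beyond the scatter) for that change. No measurement at hand offers a cause for these steps.

The compounds shown leave open whether another group at this chain end, such as an amine, a carboxylic acid or a longer chain in place of the chlorine, would shift the number beyond the scatter.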